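The source may hold more compounds than are shown below. What is called first, only, known or untested is meant among the compounds shown, and "the series" means these compounds.

Measured compounds:
compound 1 `COc1cc(/C=C/C(=O)/C=C(/C=C/c2ccc(OC(C)=O)c(OC)c2)NC2CCCCC2)ccc1OC(C)=O` gives 101% in a functional assay on EA.hy 926 cells (Homo sapiens), read by fluorescence, tested at 1 uM; on this read-out lower numbers stand for a weaker effect and higher numbers for a stronger effect at the one concentration tested
compound 2 `CCC(C)NC(=C\C(=O)/C=C/c1ccc(O)c(OC)c1)/C=C/c1ccc(O)c(OC)c1` gives 85% in this assay
compound 3 `CCC(C)NC(=C\C(=O)/C=C/c1ccc(O)cc1)/C=C/c1ccc(O)cc1` gives 99% in this assay

Compound 2 stands lowest of the three numbers in this assay. Its nearest neighbour is compound 3, whose number lies higher by a margin beyond the usual scatter; compound 1 lies further up again, also beyond the scatter. All three compounds share the same core and differ from one another in more than one place at once, so no single change among them can be isolated as a step.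

Compound 4 `COc1cc(/C=C/C(=O)/C=C(/C=C/c2ccc(O)c(OC)c2)NCC(C)C)ccc1O` has not yet been measured. It has the same atoms as compound 2, joined differently: isobutyl in place of sec-butyl on an amine nitrogen. Within the data shown here, nothing among the measured compounds tests this change on its own, since compound 1 and compound 3 differ from compound 2 at the aromatic substituents as well as at the amine.

Among the measured compounds shown here, with no step of this kind on record, the expectation is a change of no clear direction, of a size within the scatter. The estimated step of a number 2 percentage points higher from compound 2 to compound 4 (within the scatter) is accordingly small. Compound 4 is expected to give about 87% in this assay, within a range from 70% to 100%.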

Compound 4, a percentage reported as activity, at one concentration (the size of the read-out at that concentration, not a potency): 83%
Compound 4: the middle estimate sits 4 percentage points above what was measured; the range from low to high includes it.
By their numbers in this assay, from the lowest: compounds 4 and 2 (each within the scatter of the next); then compounds 3 and 1 (each within the scatter of the next).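

In this assay, among these compounds, isobutyl in place of sec-butyl on an amine nitrogen gives a number 2 percentage points lower from compound 2 to compound 4 (within the scatter), and this is the first step that isolates a single change. At this place, on a nitrogen whose other neighbour is the double-bonded chain carbon, the read-out at the one concentration tested does not tell sec-butyl and isobutyl apart, so this exchange of one 4-carbon group for the other leaves the number within the scatter. Nothing on record bears on why the two groups read alike.

The steps from compound 2 to compound 1 and to compound 3 cannot be read, since those compounds differ from it in more than one place, so the separate contributions of the amine group and the aromatic substituents stay unresolved. Also open, on these data alone, is whether a group of another kind on this nitrogen, such as a longer chain like n-octyl or a chain ending in a carboxylic acid, would shift the number beyond the scatter, and whether sec-butyl and isobutyl would still read alike at other concentrations.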